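The source may hold more compounds than are shown below. What is called first, only, known or untested is meant among the compounds shown, and "the series" means these compounds.

Measured compounds:
compound 1 `Cc1cc(-c2ccccc2)nnc1NCCCN` — > 30 mg/kg
compound 2 `Cc1cc(-c2ccccc2)nnc1NC(C)CN` — > 30 mg/kg
compound 3 `Cc1cc(-c2ccccc2)nnc1NCCCCN` — > 30 mg/kg

In a functional assay on the whole organism for positive allosteric modulation, with Mus musculus as the target (on this read-out higher numbers stand for an effect only at larger amounts of compound and lower numbers for an effect already at smaller amounts), compound 3 gives only a limit of the assay, not a number. The same holds for the other two values, so that the limit of > 30 mg/kg in this assay, at which 3 of the 3 values shown sit, applies to everything known so far. Accordingly the steps reaching compound 3, a step that the two limits leave unreadable from compound 1 to compound 3 and a step that the two limits leave unreadable from compound 2 to compound 3, like a step that the two limits leave unreadable from compound 1 to compound 2, cannot be read in size or direction.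

Compound 4 `CCN(CC)CCNc1nnc(-c2ccccc2)cc1C` differs from compound 3 by diethylamino in place of 2-aminoethyl on a saturated chain carbon, two bonds along the chain from a nitrogen on an aromatic ring. Among the measured compounds shown here, no measured step involves a diethylamino group, so nothing among the three steps speaks for a change beyond the scatter. Compound 4 is therefore expected to give about 30 mg/kg, between 10 mg/kg and 100 mg/kg, most likely again as a limit. The expected step is a number no higher from compound 3 to compound 4 (the limit leaves the size open).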

Compound 4, dose for half-maximal effect: > 30 mg/kg
Compound 4 gave a limit, no number (the forecaster's own chance of this, stated with the estimate: 70%); the middle value sits exactly at the limit.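

Compound 4 also gives only a limit in this assay, so its steps from compound 1, compound 2 and compound 3 cannot be read in size or direction: the limit of > 30 mg/kg in this assay, at which 4 of the 4 values shown sit.

The compounds shown leave open what dose for half-maximal effect compound 1, compound 2, compound 3 or compound 4 actually has in this assay.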